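This account rests on a few compounds, and the source may have more. Where it says the series, first, only, none or still open, it means among the compounds named here.

The study measures an ADME assay on HEK293-A cells (Homo sapiens) for cytotoxicity, read by MTT assay, with a stated time of 48 h; on this read-out lower numbers stand for stronger inhibition and higher numbers for weaker inhibition. Compound 1, `O=C1O[C@@H](CN2CCC(c3ccc(F)cc3)CC2)CN1c1ccc(-n2cc(-c3ccccn3)cn2)c(F)c1`, gives in this assay a value that is a limit of the assay, > 400 ug/mL. Compound 2, `CC(=O)OC[C@H]1CN(c2ccc(-n3cc(-c4ccccn4)cn3)c(F)c2)C(=O)O1`, gives in this assay likewise only a limit, > 400 ug/mL. Compound 2 therefore stands at the limit of > 400 ug/mL in this assay, at which 2 of the 2 values shown sit, and no number below that limit is known for it. Compound 3, `CCNC(=O)NC[C@H]1CN(c2ccc(-n3cc(-c4ccccn4)cn3)c(F)c2)C(=O)O1`, differs from compound 2 in one place: (ethylcarbamoyl)amino in place of acetoxy on a saturated chain carbon bound to a saturated ring carbon. No step between two measured compounds is shown, so the size of a change from compound 2 to compound 3 in this assay rests on no measured pair. Among the compounds with values here, because the two values so far sit at the limit of > 400 ug/mL in this assay, at which 2 of the 2 values shown sit, the step of a number no higher from compound 2 to compound 3 (the limit leaves the size open) is expected to be none beyond the scatter. Compound 3 is accordingly estimated at 400 ug/mL, with a range from 250 ug/mL to 700 ug/mL, most likely reported again as a limit of the assay.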

Compound 3, half-maximal inhibitory concentration: 29 ug/mL
The estimate for compound 3 lay 14-fold (1.14 log units) above the measured number; measured number outside the range, below it.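

In this assay, the substituent on a saturated chain carbon bound to a saturated ring carbon turns out to be able to move the read-out, which the earlier compounds had not shown, as both sat at a limit of the assay: the limit of > 400 ug/mL in this assay, at which 2 of the 3 values shown sit. Putting (ethylcarbamoyl)amino in place of acetoxy at this place brings an at least 13-fold lower number from compound 2 to compound 3 (1.13 log units; beyond the scatter). As far as these compounds go, compound 2 holds only a limit of the assay, so the full size of this step remains unknown.

With a single such change, the compounds shown do not tell which part of the (ethylcarbamoyl)amino group goes with the lower number. From the compounds shown here alone, whether a plain amine or an acetamide at this place, or a longer chain in place of the ethyl, would give a number like that of compound 3 stays open.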